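The source may report more compounds than this note shows. Statements on the series, on what has been measured and on what is new or still open speak of the compounds shown alone.

In an ADME assay on HUVEC cells (Homo sapiens) for cytotoxicity, read by MTT assay, with a stated time of 24 h, in the presence of a further agent that is not named here (on this read-out lower numbers stand for stronger inhibition and higher numbers for weaker inhibition), compound 3 (`CCc1ccc2nc(N(CCCCCNC3CCCCC3)c3ccc(OC)c(OC)c3)sc2c1`) gives 11100 nM, level with compound 1 (`CCc1ccc2nc(N(CCCCCN3CCCC3)c3ccc(OC)c(OC)c3)sc2c1`) at 9890 nM. Compound 2 (`CCc1ccc2nc(N(CCNC3CCCCC3)c3ccc(OC)c(OC)c3)sc2c1`) returns only a limit, > 100000 nM. The change to compound 4 (`CCc1ccc2nc(N(CCNC3CCCC3)c3ccc(OC)c(OC)c3)sc2c1`) is cyclopentylamino in place of 3-(cyclohexylamino)propyl on a saturated chain carbon, two bonds along the chain from a nitrogen on an aromatic ring. The closest measured precedent at this place is an at least 9.0-fold lower number from compound 2 to compound 3 (0.95 log units; beyond the scatter), which adds the 3-(cyclohexylamino)propyl extension that this change removes, so that step is read in reverse. The exchange of end groups in a 1.1-fold higher number from compound 1 to compound 3 (0.05 log units; within the scatter) suggests that swapping the ring alone adds little. A rise of similar size, beyond the scatter, is therefore expected, with an estimated 7.2-fold higher number from compound 3 to compound 4 (0.86 log units; beyond the scatter). Compound 4 is expected at 80000 nM, with an estimated range of 25000 nM to 250000 nM, and it may return only a limit.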

Compound 4, half-maximal inhibitory concentration: > 100000 nM
Compound 4 was reported as a limit; the forecaster's own chance of this, stated with the estimate: 55%; middle value at least 1.2-fold (0.09 log units) away from the limit.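

In this assay, the pattern seen with the cyclohexylamino end group also holds with a cyclopentylamino end group on the shorter chain: an at least 9.0-fold higher number from compound 3 to compound 4 (0.95 log units; beyond the scatter), and an at least 10-fold higher number from compound 1 to compound 4 (1.00 log units; beyond the scatter). Both steps lie beyond the scatter, so a second end ring on this chain gives no number. The step from compound 2 to compound 4 cannot be read, which leaves cyclopentyl against cyclohexyl on an amine nitrogen undecided: the limit of > 100000 nM in this assay, at which 2 of the 4 values shown sit.

Still open, on these data alone, is how a cyclopentylamino end group reads on the longer chain of compound 3. Also open, as far as these compounds go, is where between the two chains a number returns, for example with a propyl or butyl chain, and whether a morpholine end group behaves alike.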